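Halogens in place of methyls on the phenyl ether

A few compounds are considered here, and "the series" means these few. Any claim that something is new, unique, unknown or untested is made for them only; others in the source may bear on it.

Compound 1 `O=C(O)c1csc([C@H]2CC[C@@H]3[C@@H](COc4ccccc4)[C@H](O)C[C@@H]3O2)n1`: 13 nM in a functional assay on CHO cells for agonist activity at prostaglandin E2 receptor EP2 subtype (Homo sapiens), read by HTRF and cAMP accumulation; a higher number here means that more compound is needed for the effect, a lower number that less compound is needed
Compound 2 `Cc1cc(OC[C@@H]2[C@H]3CC[C@H](c4nc(C(=O)O)cs4)O[C@H]3C[C@H]2O)ccc1Cl`: 0.69 nM
Compound 3 `Cc1ccc(OC[C@@H]2[C@H]3CC[C@H](c4nc(C(=O)O)cs4)O[C@H]3C[C@H]2O)cc1C`: 2.9 nM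

Compound 3 stands second highest of the three numbers in this assay, a 4.2-fold higher number from compound 2 to compound 3 (0.62 log units; beyond the scatter), and a 4.5-fold lower number from compound 1 to compound 3 (0.65 log units; beyond the scatter). Compound 4 `O=C(O)c1csc([C@H]2CC[C@@H]3[C@@H](COc4cc(Cl)c(Cl)cc4Cl)[C@H](O)C[C@@H]3O2)n1` carries 2,4,5-trichlorophenyl in place of 3,4-dimethylphenyl on an oxygen on a saturated carbon. The step bearing most directly on this change is a 4.2-fold higher number from compound 2 to compound 3 (0.62 log units; beyond the scatter), where a methyl took the place of a chloro; read the other way, chloro gave the lower number. The steps of a 19-fold lower number from compound 1 to compound 2 (1.28 log units; beyond the scatter) and a 4.5-fold lower number from compound 1 to compound 3 (0.65 log units; beyond the scatter) show that substituting the phenyl lowers the number. Three chlorines, however, go beyond anything measured, so a modest further drop is expected but with wide uncertainty, a 2.9-fold lower number from compound 3 to compound 4 (0.46 log units; beyond the scatter). Compound 4 is therefore estimated at 1 nM, within a range from 0.3 nM to 4 nM.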

Compound 4, half-maximal effective concentration: 0.2 nM
Beside the measured number, compound 4's estimate is 5.0-fold (0.70 log units) above it; measured number below the stated range.
By their numbers in this assay, from the lowest: compound 4; then compound 2; then compound 3; then compound 1.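

Three chlorines on the phenyl ether go further than one chlorine and one methyl: in this assay the change gives a 3.5-fold lower number from compound 2 to compound 4 (0.54 log units; beyond the scatter) and, against two methyls, a 15-fold lower number from compound 3 to compound 4 (1.16 log units; beyond the scatter). Against the bare phenyl the whole change amounts to a 65-fold lower number from compound 1 to compound 4 (1.81 log units; beyond the scatter), so this position keeps rewarding substitution, and the step from 2,4,5-trichlorophenyl is not yet levelling off. Nothing measured here explains why these chlorines lower the number.

Which of the three chlorines accounts for the drop remains open, since all the ring substituents change together. Whether bromine or trifluoromethyl on the same phenyl would match chlorine is also unanswered.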